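This account rests on a few compounds, and the source may have more. Where it says the series, first, only, none or still open, it means among the compounds named here.

Measured compounds so far:
compound 1 `CC(C)Oc1cccc2ccc(N)nc12`, 437 nM
compound 2 `CCOCC(C)Oc1cccc2ccc(N)nc12`, 1070 nM
compound 3 `CCCC(C)Oc1cccc2ccc(N)nc12`, 105 nM

In an assay on cells with melanin-concentrating hormone receptor 1 (Homo sapiens) as the target, read by radioligand binding (on this read-out higher numbers stand for weaker inhibition and lower numbers for stronger inhibition), compound 3 gives 105 nM, the lowest of the three numbers; compound 1 gives 437 nM, and compound 2 gives 1070 nM. Compound 3 thus stands furthest from compound 2, with a 10-fold lower number from compound 2 to compound 3 (1.01 log units; beyond the scatter), and nearer to compound 1, with a 4.2-fold lower number from compound 1 to compound 3 (0.62 log units; beyond the scatter).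

The next compound, compound 4 `CC(COC(C)(C)C)Oc1cccc2ccc(N)nc12`, differs from compound 3 in one place: tert-butoxy in place of ethyl on a saturated chain carbon, two bonds along the chain from an oxygen on an aromatic ring.

Among the compounds with values here, three measured steps bear on this change. Adding an ether-bearing group to the chain gave a 2.4-fold higher number from compound 1 to compound 2 (0.39 log units; beyond the scatter), whereas adding a plain carbon chain gave a 4.2-fold lower number from compound 1 to compound 3 (0.62 log units; beyond the scatter), and exchanging the ether for the plain chain gave a 10-fold lower number from compound 2 to compound 3 (1.01 log units; beyond the scatter). Within the data shown here, compound 4 again carries an ether oxygen on the chain, now within a larger group, so a step back toward higher numbers is expected in this assay, most likely of modest size, though the larger group has no direct precedent among the three compounds.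

Compound 4 is therefore expected to give about 600 nM in this assay, with a likely range from 200 nM to 1800 nM, corresponding to an expected 5.7-fold higher number from compound 3 to compound 4 (0.76 log units; beyond the scatter).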

Compound 4, half-maximal inhibitory concentration: 306 nM
For compound 4 the middle estimate is 2.0-fold (0.29 log units) above the measured one; the range from low to high includes it.
By their numbers in this assay, from the lowest: compound 3; then compounds 4 and 1 (each within the scatter of the next); then compound 2.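

In this assay, tert-butoxy in place of ethyl on this chain carbon gives a 2.9-fold higher number from compound 3 to compound 4 (0.46 log units; beyond the scatter) and so extends the earlier contrast between the ethyl and ethoxy groups to a second ether-bearing group. Exchanging the ethyl on the ether oxygen for tert-butyl gives a 3.5-fold lower number from compound 2 to compound 4 (0.54 log units; beyond the scatter) and shows something new: the group on that oxygen also changes the number, and here the tert-butyl ether gives the lower one. With tert-butoxy in place of hydrogen, the step is a 1.4-fold lower number from compound 1 to compound 4 (0.15 log units; within the scatter) and the two numbers cannot be told apart, whereas ethoxy on the same carbon had moved the number beyond the scatter. The data given here offer no explanation for these steps.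

Within the data shown here, with only two ether groups in hand, it remains open how an isopropoxy group would read on this carbon and whether the number follows any trend across such groups. Going by these compounds, it also remains open how an amine or a chain longer than propyl would read here.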